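Relocating the dioxoimidazolidine on the shared core

The source may hold more compounds than are shown below. What is called first, only, known or untested is meant among the compounds shown, and "the series" means these compounds.

Two compounds share a core carrying a fluoronaphthyl group and an isopropyl-bearing chain. Compound 1 `CC(C)C(/C=C1\OC(=O)NC1=O)c1cc(Cl)c(-c2ccc3cccc(F)c3c2)[nH]c1=O` places an exocyclic oxazolidinedione on that chain, while compound 2 `CC(C)C(c1ccc(-c2ccc3cccc(F)c3c2)[nH]c1=O)C1C(=O)NC(=O)N1C` carries a 3-methyl-2,5-dioxoimidazolidin-4-yl there. In a functional assay on CHO cells for antagonist activity at prostaglandin E2 receptor EP3 subtype (Homo sapiens), read by cAMP accumulation, with a stated time of 30 min (a higher number here means a weaker inhibitor, a lower number a stronger inhibitor), compound 1 gives 360 nM, and in this assay compound 2 gives 320 nM. Compound 2 thus shows the lower of the two numbers, but the gap to compound 1 lies within the usual scatter, so the two cannot be told apart on these data.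

Compound 3 `CC(C)C(CC1NC(=O)NC1=O)c1ccc(-c2ccc3cccc(F)c3c2)[nH]c1=O` keeps every atom of compound 2 but joins them differently: (2,5-dioxoimidazolidin-4-yl)methyl in place of 3-methyl-2,5-dioxoimidazolidin-4-yl on a saturated chain carbon bound to an aromatic carbon and a saturated chain carbon. Among the compounds with values here, with no measured pair of the same kind to draw on, the step from compound 2 is expected to be small, with no clear direction beyond the scatter, as a 1.3-fold higher number from compound 2 to compound 3 (0.10 log units; within the scatter). Compound 3 is therefore estimated at 400 nM in this assay, within a range of 150 nM to 1200 nM.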

Compound 3, half-maximal inhibitory concentration: 31 nM
Compound 3: middle estimate off by 13-fold (1.11 log units), on the high side; the whole stated range lies above it.
By their numbers in this assay, from the lowest: compound 3; then compounds 2 and 1 (each within the scatter of the next).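

In this assay, the rearrangement gives a 10-fold lower number from compound 2 to compound 3 (1.01 log units; beyond the scatter), a large step beyond the scatter, so this saturated chain carbon responds strongly to how the same heavy atoms are joined, and not only to which atoms are present. The change from 3-methyl-2,5-dioxoimidazolidin-4-yl to (2,5-dioxoimidazolidin-4-yl)methyl keeps the five-membered ring and its hydrogen-bond acceptors, and the counted difference between the two groups lies in their hydrogen-bond donors. No measurement here bears on why the number falls.

Going by these compounds, the step moves the methyl from the ring to a link in a single change, so the share of each part remains open. Also open, on these data alone, is how a longer chain, such as an ethylene link to the ring, or a carboxylic acid in place of the ring would read on this carbon.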